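Trifluoromethyl in place of methyl on the ether chain

The source may report more compounds than this note shows. Statements on the series, on what has been measured and on what is new or still open speak of the compounds shown alone.

In a functional assay on A549 cells (Homo sapiens) for cytotoxicity, read by MTT assay, with a stated time of 72 h (a lower number here means that less compound is needed, a higher number that more compound is needed for the effect), compound 1 `CCc1cccc2c(OC)c(-c3occ(C)c3C(=O)OC)ccc12` gives 1.5 ug/mL. Compound 2 `CCOCc1c(C)coc1-c1ccc2c(CC)cccc2c1OC` gives > 10 ug/mL, which is a limit of the assay and not a number. Within the data shown here, the one measured step is an at least 6.6-fold higher number from compound 1 to compound 2 (0.82 log units; beyond the scatter), with ethoxymethyl in place of methoxycarbonyl on an aromatic carbon. Compound 3 `CCc1cccc2c(OC)c(-c3occ(C)c3COCC(F)(F)F)ccc12` differs from compound 2 by trifluoromethyl in place of methyl on a saturated chain carbon bound to an oxygen on a saturated carbon, which turns ethoxymethyl into (2,2,2-trifluoroethoxy)methyl. Among the measured compounds shown here, no measured step tests this exchange, and the step above bears on it only indirectly, since compound 3 keeps the ether chain and not the methoxycarbonyl. No step beyond the scatter is expected in this assay, in either direction. The expected step is a step that the limit leaves unreadable from compound 2 to compound 3. For compound 3 the estimate is 12 ug/mL, with an expected range from 5 ug/mL to 30 ug/mL.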

Compound 3, concentration for half-maximal effect: > 10 ug/mL
Compound 3: a limit, no number (the forecaster's own chance of this, stated with the estimate: 65%); the middle value lies beyond the limit too.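

In this assay compound 3 gives > 10 ug/mL, which is a limit of the assay and not a number. Changing methoxycarbonyl on an aromatic carbon to (2,2,2-trifluoroethoxy)methyl gives an at least 6.6-fold higher number from compound 1 to compound 3 (0.82 log units; beyond the scatter), so a second ether chain at this position joins the ethoxymethyl of compound 2 in giving no readable number, while only the methoxycarbonyl of compound 1 gives one. The exchange of methyl for trifluoromethyl on the ether chain cannot be sized, because compound 2 and compound 3 both stand at a limit: the limit of > 10 ug/mL in this assay, at which 2 of the 3 values shown sit.

Going by these compounds, how far either compound lies past that limit stays open, so the effect of trifluoromethyl on this chain remains unknown. Also open, on these data alone, is whether a carboxylic acid or an amide on that aromatic carbon would give a number in this assay, as the methoxycarbonyl does.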